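This account rests on a few compounds, and the source may have more. Where it says the series, first, only, none or still open, it means among the compounds named here.

Among the measured compounds shown here, compound 1 `N#Cc1ccc(Nc2nc(Oc3ccnc4ccccc34)nc(N3CCN(c4ncccn4)CC3)n2)cc1C(F)(F)F` is the only member of this small set with an actual number on the scale: in a functional assay on DU-145 cells (Homo sapiens) for cytotoxicity, read by sulforhodamine B assay, with a stated time of 48 h (on this read-out lower numbers stand for stronger inhibition of growth and higher numbers for weaker inhibition of growth), compound 1 gives 85200 nM. The two other measured compounds differ from it only in the group carried by the amine nitrogen in the ring. Compound 2 `N#Cc1ccc(Nc2nc(Oc3ccnc4ccccc34)nc(N3CCN(c4ccc(F)cc4)CC3)n2)cc1C(F)(F)F` has 4-fluorophenyl there, and its result is a limit of the assay rather than a number, > 100000 nM. Compound 3 `N#Cc1ccc(Nc2nc(Oc3ccnc4ccccc34)nc(N3CCN(Cc4ccccc4)CC3)n2)cc1C(F)(F)F` carries benzyl there, and its result is likewise a limit, > 100000 nM. Both steps away from compound 1 are therefore readable only as floors: an at least 1.1-fold higher number from compound 1 to compound 2 (0.06 log units; that floor lies within the scatter) and an at least 1.1-fold higher number from compound 1 to compound 3 (0.06 log units; that floor lies within the scatter). The remaining pair gives a step that the two limits leave unreadable from compound 2 to compound 3, since the limit of > 100000 nM in this assay, at which 2 of the 3 values shown sit, covers both of them.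

Compound 4 `CC1CC(C)CN(c2nc(Nc3ccc(C#N)c(C(F)(F)F)c3)nc(Oc3ccnc4ccccc34)n2)C1` makes a different kind of change: 3,5-dimethylpiperidin-1-yl in place of 4-(pyrimidin-2-yl)piperazin-1-yl on an aromatic carbon. For the measured compounds named here, none of the measured steps alters this part of the molecule in the same way, so they bear on it only loosely; what they share is that every result so far sits at weak growth inhibition. The expectation for compound 4 is therefore a value in the same weak region, or again a limit. Compound 4 is estimated at 90000 nM, with a range from 30000 nM to 300000 nM. That estimate corresponds to a 1.1-fold higher number from compound 1 to compound 4 (0.02 log units; within the scatter), a step expected to stay within the scatter.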

Compound 4, concentration for 50% growth inhibition: 27200 nM
Beside the measured number, compound 4's estimate is 3.3-fold (0.52 log units) above it, outside the stated range (below it).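

In this assay, among the compounds shown here, exchanging the whole 4-(pyrimidin-2-yl)piperazin-1-yl group on the aromatic carbon for 3,5-dimethylpiperidin-1-yl gives a 3.1-fold lower number from compound 1 to compound 4 (0.50 log units; beyond the scatter), the first step in this set that can be read as a real difference. The earlier steps shown here changed only the group carried on the amine nitrogen of the ring and could be read only as floors within the scatter, whereas this one replaces the entire group and shows that the read-out can respond to a change at this position. The entering group has fewer heavy atoms, fewer nitrogen atoms and no aromatic ring, but all of these differences arrive together, and nothing shown ties the step to any one of them.

On these data alone, it remains open whether a plain piperidin-1-yl group without the two methyl groups, or a morpholin-4-yl group with a ring oxygen, would give a similar number, which would help separate the role of the methyl groups from that of the ring atoms. As far as these compounds go, it is also open whether a small open-chain amine such as dimethylamino at this position would keep the step.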